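A configuration step from compound 2 to compound 3

The source may report more compounds than this note shows. Statements on the series, on what has been measured and on what is new or still open speak of the compounds shown alone.

In a functional assay on XF498 cells (Homo sapiens) for cytotoxicity (a lower number here means that less compound is needed, a higher number that more compound is needed for the effect), compound 1 (`CCCCC/C=C\C/C=C\C/C=C\C[C@@]1(OC)C=CC(=O)O1`) gives 9.9 ug/mL as a measured number. Compound 2 (`CC/C=C\C/C=C\C/C=C\C/C=C\C[C@]1(OC)C=CC(=O)O1`) gives > 30 ug/mL in this assay and this entry is a limit of the assay, not a number. The place of compound 2 is therefore known only through the limit of > 30 ug/mL in this assay, at which 1 of the 2 values shown sits, and not through a value of its own.

Compound 3 (`CC/C=C/C/C=C\C/C=C\C/C=C\C[C@@]1(OC)C=CC(=O)O1`) follows from compound 2 by a change of configuration alone. The account of that change is the two compounds have the same atoms and bonds and differ only in configuration as drawn: 2 of 5 stereo elements differ; a stereocentre at a saturated ring carbon is drawn R in compound 2 and S in compound 3; a double bond is drawn Z in compound 2 and E in compound 3 and no group enters or leaves.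

Within the data shown here, no measured step shows what such a change does in this assay so the expectation remains loose. Compound 1 at 9.9 ug/mL shows that a number can be reached in this assay among these compounds, so a small shift towards less compound needed is expected, if there is any shift at all. The expected size is an at least 1.2-fold lower number from compound 2 to compound 3 (0.07 log units; that floor lies within the scatter) as an estimate that starts from a limit. For compound 3 the expected value is 25 ug/mL with an estimated range from 10 ug/mL to 60 ug/mL in this assay and a report of only a limit remains quite possible.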

Compound 3, concentration for half-maximal effect: > 30 ug/mL
Compound 3: no number, only a limit; the forecaster's own chance of this, stated with the estimate: 50%; middle value at least 1.2-fold (0.07 log units) away from the limit.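

In this assay compound 3 gives > 30 ug/mL, and this entry is a limit of the assay, not a number. The step between compound 2 and compound 3 cannot be read, because neither compound has a value of its own: the limit of > 30 ug/mL in this assay, at which 2 of the 3 values shown sit. Among these compounds, the one step that can be read is an at least 3.0-fold higher number from compound 1 to compound 3 (0.48 log units; beyond the scatter), which goes with but-1-en-1-yl in place of butyl on a saturated chain carbon bound to a double-bonded chain carbon, so this place on the chain now has a first measured step in this assay, though one that ends at a limit and gives only a minimum size.

As far as these compounds go, whether the stereocentre at the saturated ring carbon or the double bond counts for more in this assay stays open, and neither change can be taken alone from this pair: the fact that compounds 2 and 3 differ only in the configuration as drawn. Also open, from the compounds shown here alone, is how the number would move with a carboxylic acid or an amine in place of the butyl, or with a longer chain there.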